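Swapping the oxirane substituent of compound 2 for oxolane

The source may hold more compounds than are shown below. What is called first, only, known or untested is meant among the compounds shown, and "the series" means these compounds.

Compound 1 `Cn1c(CC2(C(C)(C)C)CO2)cc(=O)n(C)c1=O`: 7900 nM
Compound 2 `C[C@H]1O[C@@]1(C)Cc1cc(=O)n(C)c(=O)n1C`: 89000 nM

In a functional assay on MDCK cells (Canis lupus familiaris) for inhibition (a higher number here means that more compound is tolerated, a lower number that less compound is tolerated), compound 2 gives 89000 nM as the higher of the two numbers. The nearest number is that of compound 1 at 7900 nM, and this gap lies beyond the scatter. Both compounds carry an oxirane-containing substituent on the shared core.

The next compound, compound 3 `Cn1c(C[C@@H]2CCCO2)cc(=O)n(C)c1=O`, has not yet been measured. Its change from compound 2 is oxolan-2-yl in place of 2,3-dimethyloxiran-2-yl on a saturated chain carbon bound to an aromatic carbon, with oxolan-2-yl in place of 2,3-dimethyloxiran-2-yl on a saturated chain carbon bound to an aromatic carbon. Among the measured compounds shown here, no measured pair differing in one place shows what such a change does, so the expectation is loose.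

Compound 2, at 89000 nM, is the closest reference, and only a small upward move in this assay is expected, not beyond the scatter. The expected step is a 1.5-fold higher number from compound 2 to compound 3 (0.16 log units; within the scatter) in this estimate. For compound 3 the estimated value is 130000 nM, with an expected range from 45000 nM to 350000 nM around it.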

Compound 3, half-maximal cytotoxic concentration: 1220000 nM
The estimate for compound 3 lay 9.4-fold (0.97 log units) below the measured number, outside the stated range (above it).
By their numbers in this assay, from the lowest: compound 1; then compound 2; then compound 3.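

In this assay, among the compounds shown here, the exchange of 2,3-dimethyloxiran-2-yl for oxolan-2-yl on a saturated chain carbon bound to an aromatic carbon gives a 14-fold higher number from compound 2 to compound 3 (1.14 log units; beyond the scatter) as the only step here between compounds that differ in one place, and it shows that this position does not treat the two groups alike. The two groups match in heavy atoms, with 4 carbon and 1 oxygen, and in hydrogen-bond donors and acceptors, so these counts do not distinguish them; what differs is a three-membered ring against a five-membered ring and 2 defined stereocentres against 1. No accompanying data bear on what lies behind a step of this size.

For the compounds shown here, the single step does not separate ring size from the two methyl groups on the oxirane ring or from the stereocentres, and a plain oxiran-2-yl group or the opposite stereoisomer of oxolan-2-yl would be needed to tell these apart. From the compounds shown here alone, it also remains open whether the number keeps rising with a six-membered oxan-2-yl ring, or whether an open methoxyethyl chain at this place would give a similar number.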